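Ester Size and Inhibition Across Two Cores

The source may hold more compounds than are shown below. What is called first, only, known or untested is meant among the compounds shown, and "the series" means these compounds.

Measured compounds:
Compound 1 `CCOC(=O)/C(C#N)=C/c1ccc(O)c(O)c1`: 57.8%
Compound 2 `CC(C)(C)OC(=O)/C(C#N)=C/c1ccc(O)c(O)c1`: 43.4%
Compound 3 `CCOC(=O)/C(C#N)=C/c1cc2ccccc2[nH]1`: 88.4%

In a functional assay on the whole organism (strain CD1) for inhibition, with Mus musculus as the target, with stated times of 15 min and 20 min, at a dose of 10 mg/kg by the subcutaneous route (on this read-out lower numbers stand for less inhibition and higher numbers for more inhibition at the one dose given (going by the name of the read-out)), compound 1 gives 57.8%, and compound 2, which carries tert-butyl in place of ethyl on an oxygen next to a carbonyl group, gives 43.4%; the step is a number 14.4 percentage points lower from compound 1 to compound 2 (beyond the scatter). Compound 3 gives 88.4%, the highest of the three. The difference between the core of compound 1 and the core of compound 3 is not broken down here.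

Compound 4 `CC(C)(C)OC(=O)/C(C#N)=C/c1cc2ccccc2[nH]1` has not yet been measured in this assay. It carries the same change relative to compound 3, namely (tert-butyl in place of ethyl on an oxygen next to a carbonyl group), that compound 2 carries relative to compound 1. Because a number 14.4 percentage points lower from compound 1 to compound 2 (beyond the scatter) was a modest loss, a similar or slightly smaller downward step is expected, giving an estimated a number 12.4 percentage points lower from compound 3 to compound 4 (beyond the scatter). Compound 4 is therefore expected to give about 76%, plausibly between 60% and 90%.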

Compound 4, a percentage reported as inhibition, in the whole organism at one dose (the size of the read-out at that dose, not a potency): 51.3%
The estimate for compound 4 lay 24.7 percentage points above the measured number; measured number below the stated range.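

In this assay, tert-butyl in place of ethyl on an oxygen next to a carbonyl group again gives a loss, here a number 37.1 percentage points lower from compound 3 to compound 4 (beyond the scatter). The direction of the change carries over from the core of compound 1 to the core of compound 3, but its size does not: the same change on two cores in this assay, a number 14.4 percentage points lower (beyond the scatter) from compound 1 to compound 2 and a number 37.1 percentage points lower (beyond the scatter) from compound 3 to compound 4, 22.7 percentage points apart, beyond the scatter of two such steps. This shows that the size of the step depends on the core in these two pairs, but it does not show why, and two cores give no rule for the size of the step on any further core.

The compounds shown leave open how a methyl, isopropyl or longer chain on that oxygen would compare with ethyl and tert-butyl. They also leave open what a carboxylic acid or an amide would give in place of the ester on either core.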